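The compounds below may be only part of what the source reports. "The series", "measured", "known", "first", "only" and "open" are said of these compounds alone.

Measured so far:
- compound 1 `Cc1nc(-c2ccc(Cl)cc2)sc1C(=O)CSc1nc(N)c(C#N)c(-c2ccc(Cl)cc2)n1`: 46.1%
- compound 2 `COc1ccc(-c2nc(SCC(=O)c3sc(-c4ccccc4)nc3C)nc(N)c2C#N)cc1`: 68.8%
- compound 3 `COc1ccc(-c2nc(C)c(C(=O)CSc3nc(N)c(C#N)c(-c4ccc(OC)cc4)n3)s2)cc1`: 35.6%

Among the measured compounds shown here, in a functional assay on U-87MG ATCC cells for antiproliferative activity against U-87 MG (Homo sapiens), read by MTT assay, with a stated time of 48 h, tested at 5 uM (on this read-out higher numbers stand for a weaker effect at the one concentration tested and lower numbers for a stronger effect), compound 2 gives the highest of the three numbers, which here means the weakest effect; compound 1 lies a number 33.2 percentage points lower from compound 2 to compound 3 (beyond the scatter) aside, its own value being beyond the scatter from compound 2, and compound 3 stands furthest, the single one-place step being a number 33.2 percentage points lower from compound 2 to compound 3 (beyond the scatter). That step, a methoxy entering on a ring carbon, changed the number by a large amount.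

Compound 4 `Cc1nc(-c2ccccc2)sc1C(=O)CSc1nc(N)c(C#N)c(-c2ccc(Cl)cc2)n1` is not yet measured. It differs from compound 2 in one place: chloro in place of methoxy on an aromatic carbon. For the measured compounds named here, no measured step makes exactly this exchange, so the only guide is that compound 1, which carries chloro on both outer rings, gives 46.1% while compound 2 gives 68.8%. Compound 4 sits between those two structures, so a moderate downward step is expected, a number 14.8 percentage points lower from compound 2 to compound 4 (beyond the scatter), with real uncertainty about its size. Compound 4 is therefore estimated at 54%, within 36% to 72%.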

Compound 4, a percentage reported as activity, at one concentration (the size of the read-out at that concentration, not a potency): 62.9%
Beside the measured number, compound 4's estimate is 8.9 percentage points below it; the range from low to high includes it.
By their numbers in this assay, from the lowest: compound 3; then compound 1; then compounds 4 and 2 (each within the scatter of the next).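

In this assay, the change from 4-methoxyphenyl to 4-chlorophenyl gives a number 5.9 percentage points lower from compound 2 to compound 4 (within the scatter), so with a plain phenyl on the other outer ring, this position does not tell these two groups apart. The other outer ring matters more: removing its chloro gives a number 16.8 percentage points higher from compound 1 to compound 4 (beyond the scatter), and read in reverse, this joins a number 33.2 percentage points lower from compound 2 to compound 3 (beyond the scatter) in showing that, in these two pairs, adding a chloro or a methoxy to that ring goes with a stronger effect. No evidence is available to explain these differences.

As far as these compounds go, only methoxy and chloro appear at this position, so whether an amine or a carboxylic acid there would shift the number remains open. Also open, from the compounds shown here alone, is whether methoxy and chloro would still read alike with a chloro on the other outer ring.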